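Amino for Chloro: Expected Growth Inhibition of Compound 3

A few compounds are considered here, and "the series" means these few. Any claim that something is new, unique, unknown or untested is made for them only; others in the source may bear on it.

compound 1 `ClCc1ccccc1Cn1cnc2c(Cl)nc(Cl)nc21`: 4360 nM
compound 2 `ClCc1cccc(Cn2cnc3c(Cl)ncnc32)c1`: 51300 nM

In a functional assay on SK-MEL-2 cells (Homo sapiens) for cytotoxicity, read by sulforhodamine B assay, with a stated time of 48 h (on this read-out lower numbers stand for stronger inhibition of growth and higher numbers for weaker inhibition of growth), compound 1 gives 4360 nM, the lowest of the two numbers shown, while compound 2 gives 51300 nM, a gap that lies beyond the usual scatter. Compound 3 `Nc1nc(Cl)c2ncn(Cc3ccccc3CCl)c2n1` has not yet been measured. It differs from compound 1 in one place: amino in place of chloro on an aromatic carbon. Within the data shown here, no measured pair shows this exchange, so its effect is not known from the data. A modest weakening of growth inhibition is expected, estimated as a 1.8-fold higher number from compound 1 to compound 3 (0.26 log units; within the scatter). Compound 3 is expected to give 8000 nM, within a range of 2000 nM to 30000 nM.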

Compound 3, concentration for total growth inhibition: 81300 nM
Compound 3: the middle estimate sits 10-fold (1.01 log units) below what was measured; the measured number lies above the stated range.
By their numbers in this assay, from the lowest: compound 1; then compounds 2 and 3 (each within the scatter of the next).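

In this assay, the group on the aromatic carbon between two ring nitrogen atoms proves to matter: amino in place of chloro gives a 19-fold higher number from compound 1 to compound 3 (1.27 log units; beyond the scatter). Among these compounds, until now, no pair of measured compounds had isolated a change at this position. Nothing available here accounts for the size of this step.

From the compounds shown here alone, whether a methoxy group or a dimethylamino group at this carbon would keep the growth inhibition of compound 1 remains open. Going by these compounds, it is also open whether a plain hydrogen there would give a number closer to compound 1 or to compound 3.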